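The source may report more compounds than this note shows. Statements on the series, on what has been measured and on what is new or still open speak of the compounds shown alone.

Working notes on the series, read in a functional assay on A-375 cells (Homo sapiens) for antiproliferative activity, read by CCK-8 assay, with a stated time of 72 h; a higher number here means a weaker inhibitor, a lower number a stronger inhibitor. Compound 1 `Nc1ccccc1NC(=O)c1ccc(Cn2cnc3c(Nc4ccccc4)nc(Cl)nc32)cc1` gives 2800 nM, compound 3 `CC(C)n1cnc2c(NCc3ccc(C(=O)Nc4ccccc4N)cc3)nc(Cl)nc21` gives 2170 nM, and compound 2 `Nc1ccccc1NC(=O)c1ccc(Cn2cnc3c(NCc4ccccc4)nc(Cl)nc32)cc1` gives 5830 nM, the highest number of the three and so the weakest inhibitor here.

Next comes compound 4 `Nc1ccccc1NC(=O)c1ccc(Cn2cnc3c(Nc4cccc(Cl)c4)nc(Cl)nc32)cc1`, with the change 3-chlorophenyl in place of benzyl on a nitrogen on an aromatic ring. For the measured compounds named here, one measured step bears on it: a 2.1-fold higher number from compound 1 to compound 2 (0.32 log units; beyond the scatter), modest and beyond the scatter, for benzyl in place of phenyl at that same place. Read backwards, this step points to a lower number on leaving benzyl. Going by the values given here, no measured pair separates 3-chlorophenyl from phenyl, so that part stays open and widens the range. A modest step towards a lower number is therefore expected in this assay. The expected step is a 2.5-fold lower number from compound 2 to compound 4 (0.40 log units; beyond the scatter). For compound 4 the estimated value is 2300 nM, with an expected range of 900 nM to 5500 nM.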

Compound 4, half-maximal inhibitory concentration: 6080 nM
Compound 4: middle estimate off by 2.6-fold (0.42 log units), on the low side, and the stated range ends below it.
By their numbers in this assay, from the lowest: compounds 3 and 1 (each within the scatter of the next); then compounds 2 and 4 (each within the scatter of the next).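

At this position in this assay, 3-chlorophenyl in place of benzyl on a nitrogen on an aromatic ring gives a 1.0-fold higher number from compound 2 to compound 4 (0.02 log units; within the scatter) and so does not separate the two compounds. The chloro group on the phenyl ring does count, with a 2.2-fold higher number from compound 1 to compound 4 (0.34 log units; beyond the scatter) for chloro in place of hydrogen on an aromatic carbon, so compound 1 now stands apart from both compound 2 and compound 4 by steps beyond the scatter. No measurement available here gives a reason for either step.

As far as these compounds go, whether a fluoro, methoxy or carboxylic acid group in place of the chloro would give a similar step remains open. So does whether chloro on the benzyl group of compound 2 would behave as it does on the phenyl group of compound 1.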